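The source may hold more compounds than are shown below. What is called first, only, known or untested is meant among the compounds shown, and "the series" means these compounds.

Measured in a functional assay on HepG2 cells (Homo sapiens) for cytotoxicity, read by MTT assay, with a stated time of 72 h; on this read-out lower numbers stand for stronger inhibition and higher numbers for weaker inhibition:
Compound 1 `Cc1ccc(-n2nc(C(=O)Nc3ccc(Oc4ncnc5[nH]ccc45)c(F)c3)c(C)cc2=O)cc1`: 18800 nM
Compound 2 `Cc1cc(=O)n(-c2ccccc2OC(F)(F)F)nc1C(=O)Nc1ccc(Oc2ncnc3[nH]ccc23)c(F)c1`: > 60000 nM, a limit of the assay
Compound 3 `Cc1cc(=O)n(-c2cccc(C(F)(F)F)c2)nc1C(=O)Nc1ccc(Oc2ncnc3[nH]ccc23)c(F)c1`: 26300 nM

Compound 1 gives 18800 nM and stands level with the only other number, a relation shown by a 1.4-fold higher number from compound 1 to compound 3 (0.15 log units; within the scatter). Compound 2 reports only a limit, > 60000 nM.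

Compound 4 `Cc1ccc(-n2nc(C(=O)Nc3ccc(Oc4ncnc5c4ccn5C)c(F)c3)c(C)cc2=O)cc1` departs from compound 1 at one place: methyl in place of hydrogen on an aromatic nitrogen. Going by the values given here, no measured step touches that nitrogen. The steps available change only the substituted phenyl group, so they bear on it indirectly: an at least 3.1-fold higher number from compound 1 to compound 2 (0.50 log units; beyond the scatter), and an at least 2.2-fold lower number from compound 2 to compound 3 (0.35 log units; beyond the scatter). A step beyond the scatter is therefore not firmly expected in this assay, though a slight rise seems likelier than a fall. The expected step is a 1.4-fold higher number from compound 1 to compound 4 (0.14 log units; within the scatter). For compound 4 the estimate is 26000 nM, with an expected range from 10000 nM to 60000 nM.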

Compound 4, half-maximal inhibitory concentration: > 60000 nM
Compound 4 gave a limit, no number; the forecaster's own chance of this, stated with the estimate: 20%; middle value at least 2.3-fold (0.36 log units) away from the limit.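

In this assay, going by these compounds alone, the earlier compounds varied only the substituted phenyl group, whereas this change shows that the aromatic nitrogen also matters: methyl in place of hydrogen there gives an at least 3.1-fold higher number from compound 1 to compound 4 (0.50 log units; beyond the scatter). Compound 4 reports a limit, > 60000 nM, and not a number. The full size of the step cannot be read, because the read-out stops at that limit: the limit of > 60000 nM in this assay, at which 2 of the 4 values shown sit.

As far as these compounds go, whether an ethyl group, a longer chain or an amine-bearing chain on this nitrogen would give a readable number remains open. So does whether methyl there would act alike alongside the 3-(trifluoromethyl)phenyl group of compound 3.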